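This account rests on a few compounds, and the source may have more. Where it says the series, first, only, none or still open, it means among the compounds named here.

In a functional assay on U-373MG ATCC cells for inhibition, with U373 MG (Homo sapiens) as the target, read by MTT assay, with a stated time of 7 days (a lower number here means a stronger inhibitor of growth, a higher number a weaker inhibitor of growth), two compounds with a shared core have been tested so far: compound 1 `COc1cccc(Cn2nnc3c(C(N)=O)ncn3c2=O)c1` and compound 2 `COc1ccc(Cn2nnc3c(C(N)=O)ncn3c2=O)cc1`. Compound 1 gives > 50000 nM, which is a limit of the assay and not a number. Compound 2 gives > 50000 nM, which is also a limit, so its standing rests on no exact number. Compound 3 `COc1ccc(Cn2nnc3c(C(N)=O)ncn3c2=O)cc1OC` differs from compound 2 in one place: methoxy in place of hydrogen on an aromatic carbon. The new methoxy sits on an aromatic carbon, ortho to a methoxy group. Going by the values given here, no measured step shows what this change does, and no shift beyond the usual scatter is expected in either direction in this assay. The expected change a step that the limit leaves unreadable from compound 2 to compound 3 is accordingly small. For compound 3, the estimated value is 60000 nM, with an expected range from 25000 nM to 100000 nM.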

Compound 3, concentration for 50% growth inhibition: > 50000 nM
Compound 3: only a limit was reported; the forecaster's own chance of this, stated with the estimate: 85%; the middle value lies beyond the limit too.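

Going by these compounds alone, no step among compound 1, compound 2 and compound 3 can be read in this assay, because all three stand at a limit and not at a number: the limit of > 50000 nM in this assay, at which 3 of the 3 values shown sit. The compounds shown leave open whether methoxy in place of hydrogen on an aromatic carbon changes growth inhibition at all.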